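The compounds below may be only part of what the source reports. "The series", "measured", "known", "first", "only" and "open" are said of these compounds alone.

Measured so far in an ADME assay on microsomes from liver (Homo sapiens) for metabolic stability, read by LC-MS, using NADPH, with a stated time of 10 min, tested at 0.5 uM; on this read-out lower numbers stand for a less stable compound and higher numbers for a more stable compound:
compound 1, `CC(=O)Nc1cc(-c2ccc(OC[C@@H](N)CC(C)C)c(F)c2)ccn1`: 90%
compound 2, `COC(=O)Nc1cc(-c2ccc(OC[C@@](C)(N)CC(C)C)c(C)c2)ccn1`: 98%
compound 3, `COC(=O)Nc1cc(-c2ccc(OC[C@@](C)(N)CC(C)C)c(F)c2)ccn1`: 82%

Compound 4, `CC(=O)Nc1cc(-c2ccc(OC[C@@H](N)CC(C)C)c(C)c2)ccn1`, is not yet measured in this assay.

Compound 1 and compound 3 differ in more than one place; the difference between the two cores is not broken down here. Compound 1 and compound 2 give values that lie within the usual scatter of each other, as do compound 1 and compound 3.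

For the measured compounds named here, the single change from compound 3 to compound 2 is methyl in place of fluoro on an aromatic carbon. In this assay this gave a number 16 percentage points higher from compound 3 to compound 2 (beyond the scatter).

The change from compound 1 to compound 4 is methyl in place of fluoro on an aromatic carbon. It is the same kind of change: the place differs only in that the methyl sits ortho to a (2-amino-4-methylpentyl)oxy group rather than to a (2-amino-2,4-dimethylpentyl)oxy group.

Beside that earlier step, a smaller step is expected from compound 1 to compound 4, a number 5 percentage points higher from compound 1 to compound 4 (within the scatter), because compound 1 already gives 90% and the read-out cannot exceed full recovery. Compound 4 is thus estimated at 95%, between 87% and 100%.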

Compound 4, percent of the compound remaining: 91%
Compound 4: middle estimate off by 4 percentage points, on the high side; low and high end bracket the measured number.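

In this assay, methyl in place of fluoro on the aromatic carbon gives a number 1 percentage points higher from compound 1 to compound 4 (within the scatter), so the size of the step does not carry over between the two cores: the same change on two cores in this assay, a number 16 percentage points higher (beyond the scatter) from compound 3 to compound 2 and a number 1 percentage points higher (within the scatter) from compound 1 to compound 4, 15 percentage points apart, beyond the scatter of two such steps

The step seen on the core of compound 3 therefore cannot be taken as a fixed increment for this change across the series. For the compounds shown here, what this does not show is which feature of the cores goes with the gap: the cores differ in more than one place, no pair here separates those places, and two cores say nothing about how the change would read on a third.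

Open, on these data alone, is the reading of the same change with the acetamide paired with the (2-amino-2,4-dimethylpentyl)oxy group, or the methyl carbamate paired with the (2-amino-4-methylpentyl)oxy group. Also open, as far as these compounds go, is how chloro, methoxy or a nitrile on that aromatic carbon would read on either core.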